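The source may hold more compounds than are shown below. What is called first, only, known or untested is meant among the compounds shown, and "the series" means these compounds.

Compound 1 `COCCOCn1cc(C#N)c2c(N)ncnc21` is the reference point of this set. In a functional assay on KB cells (Homo sapiens) for cytotoxicity (on this read-out lower numbers stand for stronger inhibition and higher numbers for weaker inhibition), compound 1 returns only the assay limit, > 100000 nM. Compound 2 `N#Cc1cn(COCc2ccccc2)c2ncnc(N)c12` likewise sits at the limit in this assay, giving > 100000 nM. Compound 3 `COCCOCn1cc(C(N)=O)c2c(N)ncnc21` also returns the limit, > 100000 nM. Both measured steps, a step that the two limits leave unreadable from compound 1 to compound 2 and a step that the two limits leave unreadable from compound 1 to compound 3, stay unreadable because of the limit of > 100000 nM in this assay, at which 3 of the 3 values shown sit. Compound 4 `N#Cc1c[nH]c2ncnc(N)c12` differs from compound 1 by hydrogen in place of (2-methoxyethoxy)methyl on an aromatic nitrogen. Neither measured step touches this part of the structure, so no reading of the change can be drawn from them. With every value of the series at the limit, compound 4 is expected to remain there as well, with an estimated step that the limit leaves unreadable from compound 1 to compound 4. The estimate for compound 4 is 150000 nM, with a range from 50000 nM to 500000 nM.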

Compound 4, half-maximal inhibitory concentration: 18000 nM
Beside the measured number, compound 4's estimate is 8.3-fold (0.92 log units) above it, and the stated range ends above it.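

In this assay, among the compounds shown here, the aromatic nitrogen is the first position where a change gives a readable result: hydrogen in place of (2-methoxyethoxy)methyl gives an at least 5.5-fold lower number from compound 1 to compound 4 (0.74 log units; beyond the scatter). Compound 4 is the only compound shown with a value inside the measured range, and it carries no group on this nitrogen. The value of compound 1 is a limit, so the step gives only a minimum size: the limit of > 100000 nM in this assay, at which 3 of the 4 values shown sit.

The compounds shown leave open whether a methyl group or a short aminoethyl chain on this nitrogen would stay at the limit. Going by these compounds, whether carbamoyl in place of cyano is tolerated when this nitrogen bears hydrogen also remains open.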